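Replacing the ethoxycarbonyl group of compound 2

The source may report more compounds than this note shows. Statements on the series, on what has been measured and on what is new or still open speak of the compounds shown alone.

Measured in a functional assay (trachea) with Cavia porcellus as the target; on this read-out lower numbers stand for stronger inhibition and higher numbers for weaker inhibition:
- compound 1 `O=c1c2ccccc2c(-c2cccnc2)nn1CC1CCCCC1`: 209 nM
- compound 2 `CCOC(=O)Cn1nc(-c2cccnc2)c2ccccc2c1=O`: 43700 nM

Compound 2 holds the higher, weaker of these two numbers. Compound 3 `O=c1c2ccccc2c(-c2cccnc2)nn1CCSc1ccccc1` has (phenylsulfanyl)methyl in place of ethoxycarbonyl on a saturated chain carbon bound to an aromatic nitrogen. Within the data shown here, the one measured step that bears on this is a 210-fold higher number from compound 1 to compound 2 (2.32 log units; beyond the scatter), a large change that brought in ethoxycarbonyl in place of cyclohexyl. Removing ethoxycarbonyl here should therefore give a large move toward a lower number in this assay, although a single step is thin evidence. The expected change is a 73-fold lower number from compound 2 to compound 3 (1.86 log units; beyond the scatter). For compound 3 the estimated value is 600 nM, with an expected range of 120 nM to 3000 nM.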

Compound 3, half-maximal inhibitory concentration: 9120 nM
The estimate for compound 3 lay 15-fold (1.18 log units) below the measured number, and the stated range ends below it.
By their numbers in this assay, from the lowest: compound 1; then compound 3; then compound 2.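

In this assay the change to (phenylsulfanyl)methyl gives only a 4.8-fold lower number from compound 2 to compound 3 (0.68 log units; beyond the scatter) and still leaves a 44-fold higher number from compound 1 to compound 3 (1.64 log units; beyond the scatter). Losing ethoxycarbonyl therefore does not by itself restore the low number of compound 1: the group that enters at this saturated chain carbon also counts, and here a six-membered aromatic ring of carbon only, reached through sulfur, does not match cyclohexyl. Nothing available explains this difference. Still open, on these data alone, is whether an amine, a carboxylic acid or a longer chain ending in cyclohexyl would come closer to compound 1 or move further from it.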